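The source may report more compounds than this note shows. Statements on the series, on what has been measured and on what is new or still open speak of the compounds shown alone.

In an assay on microsomes from intestine for inhibition of acyl-CoA:cholesterol acyltransferase (Oryctolagus cuniculus) (on this read-out higher numbers stand for weaker inhibition and lower numbers for stronger inhibition), compound 1 `Cc1cc(C)c(NC(=O)N(Cc2ccc(-c3nnc(C)o3)cc2)C2CCCCCC2)c(C)c1` gives 27 nM. Two companions differ from it in several places at once: compound 2 `O=C(Nc1c(F)cc(F)cc1F)N(Cc1cccc(-c2cc[nH]n2)c1)C1CCCCCC1` gives 22 nM in this assay, and compound 3 `Cc1cc(C)c(NC(=O)N(Cc2cccc(-c3cc[nH]n3)c2)C2CCCCC2)c(C)c1` gives 39 nM. Compound 1 thus sits second highest of the three numbers, yet its gaps to compound 2 and to compound 3 both fall within the usual scatter, so the three are not told apart. The untested compound 4 `Cc1cc(C)c(NC(=O)N(Cc2ccc(-n3cccn3)cc2)C2CCCCCC2)c(C)c1` differs from compound 1 in one place: 1H-pyrazol-1-yl in place of 5-methyl-1,3,4-oxadiazol-2-yl on an aromatic carbon. Going by the values given here, no measured pair shows this change, so only a small step is expected, none beyond the scatter, in either direction. Compound 4 is therefore estimated at 30 nM, between 12 nM and 80 nM, a step of a 1.1-fold higher number from compound 1 to compound 4 (0.05 log units; within the scatter).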

Compound 4, half-maximal inhibitory concentration: 70 nM
The estimate for compound 4 lay 2.3-fold (0.37 log units) below the measured number; measured number inside the range.
By their numbers in this assay, from the lowest: compounds 2, 1, 3 and 4 (each within the scatter of the next, the first and the last beyond it).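

In this assay, the position para to a large group proves sensitive to which five-membered aromatic ring it carries: 1H-pyrazol-1-yl in place of 5-methyl-1,3,4-oxadiazol-2-yl gives a 2.6-fold higher number from compound 1 to compound 4 (0.41 log units; beyond the scatter), a modest loss of inhibition. Going by these compounds alone, this is the first comparison in the set that changes only one place, and it shows that these two rings are not interchangeable here. Nothing measured here accounts for the step. From the compounds shown here alone, whether a carboxylic acid or an amine at this position would match compound 1 stays open, as does whether the step carries over to the trifluorophenyl urea of compound 2.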